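The source may hold more compounds than are shown below. What is called first, only, known or untested is meant among the compounds shown, and "the series" means these compounds.

Of the compounds shown here, three have been tested in a functional assay on CHO cells for antagonist activity at 5-hydroxytryptamine receptor 6 (Homo sapiens), read by FLIPR; on this read-out higher numbers stand for weaker inhibition and lower numbers for stronger inhibition. Compound 1 `COc1ccc(S(=O)(=O)N2CC(C(=O)NC3CCN(Cc4ccccc4)CC3)c3ccccc32)c2ccccc12` gives 50.1 nM in this assay. Compound 2 `COc1ccc(S(=O)(=O)N2CC(C(=O)N3CCNCC3)c3ccccc32)c2ccccc12` gives 7.94 nM in this assay. Compound 3 `CN1CCC(N(C)C(=O)C2CN(S(=O)(=O)c3cccc4c(Cl)cccc34)c3ccccc32)CC1` gives 5.01 nM in this assay, the lowest of the three numbers; its value and that of compound 2 lie within the scatter of each other, so no order between them can be read, while the number for compound 1 is beyond the scatter above it.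

The next step leads from compound 3 to compound 4 `COc1ccc(S(=O)(=O)N2CC(C(=O)N(C)C3CCN(C)CC3)c3ccccc32)c(C)c1C`, which is not yet measured in this assay. The change is 4-methoxy-2,3-dimethylphenyl in place of 5-chloronaphthalen-1-yl on a sulfonyl sulfur. Going by the values given here, no measured pair in this set shows this change, so its effect can only be guessed. A moderate rise in the number, that is somewhat weaker inhibition, is expected, but the step could also fall inside the scatter. Compound 4 is estimated to give 12 nM in this assay, within a range from 3 nM to 50 nM, which corresponds to an expected step of a 2.4-fold higher number from compound 3 to compound 4 (0.38 log units; beyond the scatter).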

Compound 4, inhibition constant: 100 nM
For compound 4 the middle estimate is 8.3-fold (0.92 log units) below the measured one, outside the stated range (above it).
By their numbers in this assay, from the lowest: compounds 3 and 2 (each within the scatter of the next); then compounds 1 and 4 (each within the scatter of the next).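

In this assay, the group on the sulfonyl sulfur has a strong influence on this scaffold: replacing 5-chloronaphthalen-1-yl with 4-methoxy-2,3-dimethylphenyl gives a 20-fold higher number from compound 3 to compound 4 (1.30 log units; beyond the scatter) and thus much weaker inhibition. Going by these compounds alone, no earlier pair differed in only one place, so this is the first direct reading of what a single change does in this set. Nothing measured here accounts for the size of this step.

The change removes one of two aromatic rings and the chlorine while adding methoxy and methyl groups, so the compounds shown cannot separate these contributions. A plain phenyl or an unsubstituted naphthalen-1-yl group on the same sulfonyl sulfur would help show which part of the change matters.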